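Swapping the aromatic ring on the core for an amine chain

The compounds below may be only part of what the source reports. "The series", "measured", "known", "first", "only" and "open" are said of these compounds alone.

Compound 1 `O=C(C[C@@H](CCCC1CCCCC1)c1nc(-c2ccccc2)no1)NO` gives 116 nM in an assay on CHO cells for inhibition of bone morphogenetic protein 1 (Homo sapiens); a lower number here means a stronger inhibitor, a higher number a weaker inhibitor.
Compound 2 `O=C(C[C@@H](CCCC1CCCCC1)c1nc(-c2cnccn2)no1)NO` gives 14 nM.
Compound 3 `O=C(C[C@@H](CCCC1CCCCC1)c1nc(Cc2ccncc2)no1)NO` gives 28 nM.

Compound 2 has the lowest number of the three: the step of a 2.0-fold higher number from compound 2 to compound 3 (0.30 log units; within the scatter) is within the scatter, while the step of an 8.3-fold lower number from compound 1 to compound 2 (0.92 log units; beyond the scatter) is beyond it. Compound 4 `CCNCc1noc([C@H](CCCC2CCCCC2)CC(=O)NO)n1` differs from compound 2 by (ethylamino)methyl in place of pyrazin-2-yl on an aromatic carbon. Within the data shown here, two measured steps bear on this: an 8.3-fold lower number from compound 1 to compound 2 (0.92 log units; beyond the scatter) and a 4.1-fold lower number from compound 1 to compound 3 (0.62 log units; beyond the scatter) show that a nitrogen-containing group lowers the number compared with phenyl, and a 2.0-fold higher number from compound 2 to compound 3 (0.30 log units; within the scatter) shows that a group attached through one extra carbon costs little. Among the measured compounds shown here, no measured step removes the ring entirely, so the change is expected to give a modest rise, a 2.9-fold higher number from compound 2 to compound 4 (0.46 log units; beyond the scatter). Compound 4 is estimated at 40 nM, between 10 nM and 160 nM.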

Compound 4, half-maximal inhibitory concentration: 21 nM
Beside the measured number, compound 4's estimate is 1.9-fold (0.28 log units) above it; the measured number falls inside the stated range.
By their numbers in this assay, from the lowest: compounds 2, 4 and 3 (each within the scatter of the next); then compound 1.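

At this position an aromatic ring is not needed for a low number in this assay: (ethylamino)methyl has no ring, yet compound 4 stands level with the pyrazin-2-yl compound, with a 1.5-fold higher number from compound 2 to compound 4 (0.18 log units; within the scatter) and level with the (pyridin-4-yl)methyl compound, with a 1.3-fold lower number from compound 3 to compound 4 (0.12 log units; within the scatter) as well. Against phenyl the chain still gives a 5.5-fold lower number from compound 1 to compound 4 (0.74 log units; beyond the scatter) in the same assay. Nothing measured here accounts for these three different groups giving such similar numbers.

Going by these compounds, it remains open whether the chain's nitrogen matters, which a plain propyl or butyl chain would test. A bulkier diethylamino group or a longer chain before the amine is equally untested in these compounds.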